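Chlorophenyl amides on a pyridinyl-chlorophenyl core: moving the chlorine

A few compounds are considered here, and "the series" means these few. Any claim that something is new, unique, unknown or untested is made for them only; others in the source may bear on it.

Measured so far:
Compound 1, `O=C(Nc1ccc(Cl)c(-c2ccccn2)c1)c1ccccc1Cl`: 110 nM
Compound 2, `O=C(Nc1ccc(Cl)c(-c2ccccn2)c1)c1cccc(Cl)c1`: 1500 nM

Both compounds share the core of compound 1 and differ only in the chlorophenyl group on the carbonyl carbon. In an assay on C3H 10T1/2 cells for inhibition of Sonic hedgehog protein (Mus musculus), read by a luciferase reporter (on this read-out lower numbers stand for stronger inhibition and higher numbers for weaker inhibition), compound 1 gives 110 nM and compound 2 gives 1500 nM. Going by the values given here, the single measured step, a 14-fold higher number from compound 1 to compound 2 (1.13 log units; beyond the scatter), is large, and compound 2 therefore stands at the higher end of the two numbers known in this assay.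

Compound 3, `O=C(Nc1ccc(Cl)c(-c2ccccn2)c1)c1ccc(Cl)cc1`, carries the change (4-chlorophenyl in place of 3-chlorophenyl on a carbonyl carbon). Among the compounds with values here, no measured step covers this exact exchange; the step from compound 1 to compound 2 shows only that shifting the chlorine on the benzoyl ring can move the number a great deal in this assay, and it gives no guidance on direction for the present move. Given that the only comparison available, a 14-fold higher number from compound 1 to compound 2 (1.13 log units; beyond the scatter), went toward weaker inhibition as the chlorine was moved away from the 2-position, a further move is expected to leave the number near that of compound 2 or raise it somewhat. For compound 3 the expected step is a 1.3-fold higher number from compound 2 to compound 3 (0.12 log units; within the scatter). The estimate for compound 3 is 2000 nM, with a range from 500 nM to 8000 nM.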

Compound 3, half-maximal inhibitory concentration: 1500 nM
Beside the measured number, compound 3's estimate is 1.3-fold (0.12 log units) above it, within the range that was stated.
By their numbers in this assay, from the lowest: compound 1; then compounds 2 and 3 (each within the scatter of the next).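

In this assay, 4-chlorophenyl and 3-chlorophenyl on the carbonyl carbon cannot be told apart, with no change at the digits printed from compound 2 to compound 3 (within the scatter) and so no gradient between these two groups. Measured against 2-chlorophenyl, 4-chlorophenyl gives a 14-fold higher number from compound 1 to compound 3 (1.13 log units; beyond the scatter), a large step that matches the one already seen for 3-chlorophenyl, so among the three chlorophenyl amides only compound 1 stands apart, with the lowest number and a large step to each of the other two. The series offers no independent measurement that accounts for the separation of 2-chlorophenyl from the other two groups.

Still open, as far as these compounds go, is whether the low number of compound 1 depends on chlorine itself or would persist with methyl, methoxy or fluorine in place of the chlorine of 2-chlorophenyl, and whether a second chlorine on the same ring would lower or raise the number. Also open, from the compounds shown here alone, is whether the same separation among the three chlorophenyl groups would hold if the shared core carried a further group, such as an amine or a carboxylic acid.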